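Swapping chloro for trifluoromethyl at the solubility limit

The source may report more compounds than this note shows. Statements on the series, on what has been measured and on what is new or still open speak of the compounds shown alone.

Measured so far in a physicochemical assay for solubility, read by HPLC; on this read-out lower numbers stand for lower solubility and higher numbers for higher solubility:
Compound 1 `O=C(Nc1ccc([N+](=O)[O-])c(Cl)c1)c1cc(Cl)ccc1O`: 5.1 ug/mL
Compound 2 `O=C(Nc1cccc(Cl)c1)c1cc(Cl)ccc1O`: < 1 ug/mL

Compound 2 gives < 1 ug/mL, and this is a limit of the assay, not a number. Its exact place on the scale is therefore unknown. Compound 3 `O=C(Nc1cccc(C(F)(F)F)c1)c1cc(Cl)ccc1O` differs from it in a single place, with trifluoromethyl in place of chloro on an aromatic carbon. For the measured compounds named here, the only measured step is an at least 5.1-fold lower number from compound 1 to compound 2 (0.70 log units; beyond the scatter), and there hydrogen comes in place of nitro on an aromatic carbon. That step shows that one exchange on the shared core can move the read-out beyond the scatter, but it is a different exchange and gives no direct size for this one. The point to keep in view is the limit of < 1 ug/mL in this assay, at which 1 of the 2 values shown sits. The expectation has only one anchor, compound 2, at < 1 ug/mL, again a limit. No step beyond the scatter is expected in this assay, and the estimated step is a step that the limit leaves unreadable from compound 2 to compound 3. The expected value for compound 3 is 0.8 ug/mL, with an estimated range from 0.3 ug/mL to 2.5 ug/mL.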

Compound 3, solubility: 8.4 ug/mL
For compound 3 the middle estimate is 11-fold (1.02 log units) below the measured one, and the stated range ends below it.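

In this assay, trifluoromethyl in place of chloro, on an aromatic carbon meta to a large group, gives an at least 8.4-fold higher number from compound 2 to compound 3 (0.92 log units; beyond the scatter). Compound 2 gives < 1 ug/mL, which is a limit of the assay and not a number. The earlier step concerned only the loss of nitro, whereas this one shows that the number can also move beyond the scatter at this other place, in an exchange where neither the group leaving nor the group entering carries a hydrogen-bond donor, a hydrogen-bond acceptor or a net charge.

The true size of the step stays unread, and that uncertainty rests on a single point on the scale: the limit of < 1 ug/mL in this assay, at which 1 of the 3 values shown sits. Also open are why the number rose, for which the compounds shown offer no measured reason, and whether other groups at this place, such as methyl, nitrile, an amine or a carboxylic acid, would give a higher or a lower number than trifluoromethyl.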